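Halogen swap on the aryl ring: notes toward compound 4

This account rests on a few compounds, and the source may have more. Where it says the series, first, only, none or still open, it means among the compounds named here.

Measured in a functional assay on HepG2 cells (Homo sapiens) for antiproliferative activity, read by MTT assay, with a stated time of 72 h; a higher number here means a weaker inhibitor, a lower number a stronger inhibitor:
compound 1 `Cn1nc(-c2nnc(-c3cccc(Cl)c3)o2)c2ccccc21` gives 21400 nM
compound 2 `Cn1nc(-c2nnc(-c3cccc(Br)c3)o2)c2ccccc21` gives 24500 nM
compound 3 `Cn1nc(-c2nnc(-c3ccc(Cl)cc3)o2)c2ccccc21` gives 42000 nM

Compound 4 `Cn1nc(-c2nnc(-c3ccc(Br)cc3)o2)c2ccccc21` is not yet measured in this assay. Compound 1 and compound 2 differ by bromo in place of chloro on an aromatic carbon; the step was a 1.1-fold higher number from compound 1 to compound 2 (0.06 log units; within the scatter). Compound 3 and compound 4 differ by bromo in place of chloro on an aromatic carbon. The cores differ by 4-chlorophenyl in place of 3-chlorophenyl on an aromatic carbon. The two place lines are not the same word for word: in compound 1 the halogen sits meta to a large group, in compound 3 para to a large group, so the change from compound 3 to compound 4 is the same kind of change, not the same. The step from compound 3 to compound 4 is expected to be a 1.1-fold higher number from compound 3 to compound 4 (0.04 log units; within the scatter), beside a 1.1-fold higher number from compound 1 to compound 2 (0.06 log units; within the scatter), because a 1.1-fold higher number from compound 1 to compound 2 (0.06 log units; within the scatter) stayed within the scatter. Compound 4 is estimated at 46000 nM, expected between 20000 nM and 100000 nM.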

Compound 4, half-maximal inhibitory concentration: 40000 nM
Beside the measured number, compound 4's estimate is 1.2-fold (0.06 log units) above it; the range from low to high includes it.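

In this assay, bromo in place of chloro gives a 1.1-fold lower number from compound 3 to compound 4 (0.02 log units; within the scatter). This change carries from one core to the other without a step beyond the scatter: the same change on two cores in this assay, a 1.1-fold higher number (0.06 log units; within the scatter) from compound 1 to compound 2 and a 1.1-fold lower number (0.02 log units; within the scatter) from compound 3 to compound 4, 1.2-fold (0.08 log units) apart, within the scatter of two such steps. The other new steps, a 1.6-fold higher number from compound 2 to compound 4 (0.21 log units; within the scatter) and a 1.9-fold higher number from compound 1 to compound 4 (0.27 log units; within the scatter), also stay within the scatter, so these values do not separate 4-bromophenyl from 3-bromophenyl or 3-chlorophenyl. This shows agreement only between two steps too small to read, and it does not show that a step of real size would carry across the two cores.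

Still open, going by these compounds, is whether another group at this place, such as an amine, a carboxylic acid or a methoxy group, would give a step beyond the scatter on either core. If one did, it would remain to be seen whether that step held on the other core.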